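The source may report more compounds than this note shows. Statements on the series, on what has been measured and on what is new or still open speak of the compounds shown alone.

Measured so far: compound 1 `CC1=CCCC(C)(C)C1/C=C/C(=O)/C=C/c1ccccc1F`, compound 2 `CC1=CCCC(C)(C)C1/C=C/C(=O)/C=C/c1cc(C(F)(F)F)ccc1F`, compound 3 `CC1=C(/C=C/C(=O)/C=C/c2ccccc2)C(C)(C)CCC1O`.

In a functional assay on LNCaP C4-2B cells (Homo sapiens) for cytotoxicity, read by MTT assay, with a stated time of 72 h (a lower number here means a stronger inhibitor, a higher number a weaker inhibitor), compound 1 gives 6000 nM, compound 2 gives 4700 nM and compound 3 gives 1800 nM. Compound 4 `CC1=C(/C=C/C(=O)/C=C/c2cccc(C(F)(F)F)c2)C(C)(C)CCC1O` has not yet been measured. Compound 2 differs from compound 1 by trifluoromethyl in place of hydrogen on an aromatic carbon, and that change gave a 1.3-fold lower number from compound 1 to compound 2 (0.11 log units; within the scatter). Compound 4 differs from compound 3 by trifluoromethyl in place of hydrogen on an aromatic carbon, the same kind of change; in compound 2, though, the place is also para to a fluoro group, which is not so in compound 4. How the core of compound 3 differs from the core of compound 1 is not broken down here. The expected step is a 1.2-fold lower number from compound 3 to compound 4 (0.08 log units; within the scatter), and this rests on a 1.3-fold lower number from compound 1 to compound 2 (0.11 log units; within the scatter). Compound 4 is therefore expected to give about 1500 nM, probably between 700 nM and 3500 nM.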

Compound 4, half-maximal inhibitory concentration: 1400 nM
Estimate against measurement, compound 4: 1.1-fold (0.03 log units) above, within the range that was stated.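

In this assay, trifluoromethyl in place of hydrogen on an aromatic carbon gives a 1.3-fold lower number from compound 3 to compound 4 (0.11 log units; within the scatter), and the same change on the other core gives a matching step: the same change on two cores in this assay, a 1.3-fold lower number (0.11 log units; within the scatter) from compound 1 to compound 2 and a 1.3-fold lower number (0.11 log units; within the scatter) from compound 3 to compound 4, 1.0-fold (0.00 log units) apart, within the scatter of two such steps. In these two pairs, then, the change carries from one core to the other with the same small size. Yet each step lies within the scatter, so neither pair shows that trifluoromethyl moves the number at all, and two pairs say nothing about any further core.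

The compounds shown leave open what an amine or a carboxylic acid would do in place of trifluoromethyl on the aromatic ring. They also leave open whether a larger step would carry across these cores as closely.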